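The compounds below may be only part of what the source reports. "The series", "measured", "known", "first", "only" and "open" are said of these compounds alone.

In a functional assay on CHO cells for agonist activity at Free fatty acid receptor 1 (Homo sapiens), read by FLIPR and calcium flux (on this read-out lower numbers stand for an effect already at smaller amounts and higher numbers for an effect only at larger amounts of compound), compound 2 `O=C(O)CS(=O)(=O)c1ccc(OCc2cccc(-c3ccccc3Cl)c2)cc1` gives 28.8 nM. Compound 1 `COc1cc(C)c(-c2cccc(COc3ccc4c(c3)S(=O)(=O)CC4CC(=O)O)c2)c(C)c1` reaches only the limit of this assay, > 1000 nM. Compound 2 thus stands with the only number shown, the other value being a limit, and no step between two measured compounds is available for comparison. Compound 3 `Cc1ccc(C)n1-c1cccc(COc2ccc(S(=O)(=O)CC(=O)O)cc2)c1` arises from compound 2 by the change (2,5-dimethyl-1H-pyrrol-1-yl in place of 2-chlorophenyl on an aromatic carbon). For compound 3 a modest weakening is expected, a step of a 2.1-fold higher number from compound 2 to compound 3 (0.32 log units; beyond the scatter) in this assay. Compound 3 is accordingly estimated at 60 nM, within a range from 20 nM to 200 nM.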

Compound 3, half-maximal effective concentration: 129 nM
Beside the measured number, compound 3's estimate is 2.2-fold (0.33 log units) below it, within the range that was stated.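

In this assay the exchange of 2-chlorophenyl for 2,5-dimethyl-1H-pyrrol-1-yl on an aromatic carbon, meta to a large group, gives a 4.5-fold higher number from compound 2 to compound 3 (0.65 log units; beyond the scatter) and so shows that this place responds to the ring it carries. Compound 3 still gives a number rather than a limit, so a five-membered aromatic ring with 1 hetero atom keeps measurable activity here. Nothing shown accounts for the size of this step.

Which part of the exchange carries the step stays open. So does how an unsubstituted phenyl or a morpholine would read at this place.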